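Swapping the alpha substituent of an anilide on a shared core

This account rests on a few compounds, and the source may have more. Where it says the series, first, only, none or still open, it means among the compounds named here.

In a functional assay on HT-29 cells (Homo sapiens) for cytotoxicity, read by MTT assay, with a stated time of 24 h, tested at 80 ug/mL (a lower number here means a weaker effect, a higher number a stronger effect of the compound at the concentration tested), compound 1 `Cn1c(-c2ccc(NC(=O)CCl)cc2)nc(-c2ccccc2)c1-c1ccccc1` gives 76.1%. Compound 2 `Cc1ccc2oc(SCC(=O)Nc3ccc(-c4nc(-c5ccccc5)c(-c5ccccc5)n4C)cc3)nc2c1` gives 69.8% in this assay, and compound 3 `Cn1ccnc1SCC(=O)Nc1ccc(-c2nc(-c3ccccc3)c(-c3ccccc3)n2C)cc1` gives 69.4%. The step of a number 6.3 percentage points lower from compound 1 to compound 2 (within the scatter) and the step of a number 6.7 percentage points lower from compound 1 to compound 3 (within the scatter) both stay within the scatter, as does the step of a number 0.4 percentage points lower from compound 2 to compound 3 (within the scatter), so compound 3 is not separated beyond the scatter from either of the other two compounds; the three numbers form one group.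

Compound 4 `CN1CCN(CC(=O)Nc2ccc(-c3nc(-c4ccccc4)c(-c4ccccc4)n3C)cc2)CC1` is not yet measured in this assay. It differs from compound 3 in one place: 4-methylpiperazin-1-yl in place of (1-methyl-1H-imidazol-2-yl)sulfanyl on a saturated chain carbon bound to a carbonyl carbon. The three measured steps all concern exactly this position on the saturated chain carbon bound to a carbonyl carbon, where chloro, (5-methyl-1,3-benzoxazol-2-yl)sulfanyl and (1-methyl-1H-imidazol-2-yl)sulfanyl were exchanged for one another, and none of them moved the read-out beyond the scatter. On that basis no step beyond the scatter is expected for compound 4 in this assay, and the step of a number 1.4 percentage points lower from compound 3 to compound 4 (within the scatter) is the expected one. Compound 4 is therefore estimated to give 68% in this assay, with a range from 55% to 80%.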

Compound 4, a percentage reported as activity, at one concentration (the size of the read-out at that concentration, not a potency): 53.1%
Compound 4: the middle estimate sits 14.9 percentage points above what was measured; the whole stated range lies above it.
By their numbers in this assay, from the lowest: compound 4; then compounds 3, 2 and 1 (each within the scatter of the next).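

In this assay, the position on a saturated chain carbon bound to a carbonyl carbon no longer looks indifferent to its substituent: the step of a number 16.3 percentage points lower from compound 3 to compound 4 (beyond the scatter), the step of a number 16.7 percentage points lower from compound 2 to compound 4 (beyond the scatter) and the step of a number 23 percentage points lower from compound 1 to compound 4 (beyond the scatter) all pass the scatter, whereas chloro and the two sulfanyl groups stayed within it of one another. The change from compound 3 to compound 4 keeps the same heavy-atom count in the group exchanged and removes the sulfur, replacing a five-membered aromatic ring with a six-membered non-aromatic ring, so heavy-atom count alone does not account for the separation of these two compounds. No measured evidence accompanies these compounds that would tie the lower number to any property of the 4-methylpiperazin-1-yl group.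

The compounds shown leave open whether the lower number is specific to 4-methylpiperazin-1-yl or also extends to other amines on this carbon, such as a morpholin-4-yl ring, a piperidin-1-yl ring or an open-chain dimethylamino group. Also open, on these data alone, is how the effects of the four compounds compare at other concentrations: each number gives the size of the read-out at a single concentration.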